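A few compounds are considered here, and "the series" means these few. Any claim that something is new, unique, unknown or untested is made for them only; others in the source may bear on it.

Measured so far in an ADME assay (Rattus norvegicus) for metabolic stability; on this read-out higher numbers stand for a longer-lived compound and lower numbers for a shorter-lived compound:
- compound 1 `C=C[C@@H]1C[C@]1(NC(=O)[C@@H]1[C@H](CC)[C@@H]2CN1C(=O)[C@H](C(C)(C)C)NC(=O)O[C@@H]1C[C@H]1CCCCCc1nc3ccc(OC)cc3nc1O2)C(=O)NS(=O)(=O)C1CC1`: 2.2 h
- compound 2 `CC[C@@H]1[C@@H]2CN(C(=O)[C@H](C(C)(C)C)NC(=O)O[C@@H]3C[C@H]3CCCCCc3nc4ccc(OC)cc4nc3O2)[C@@H]1C(=O)N[C@]1(C(=O)NS(=O)(=O)C2CC2)C[C@H]1CC`: 5 h

For the measured compounds named here, compound 2 holds the higher of the two numbers, at 5 h, and compound 1 is its only neighbour. Going by the values given here, the one measured step, a 2.3-fold higher number from compound 1 to compound 2 (0.36 log units; beyond the scatter), is ethyl in place of vinyl on a saturated ring carbon. It lies beyond the scatter but is modest.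

The next compound is compound 3 `CC[C@@H]1[C@@H]2CN(C(=O)[C@H](C(C)(C)C)NC(=O)O[C@@H]3C[C@H]3CCCCCc3nc4ccc(OC)cc4nc3O2)[C@@H]1C(=O)N[C@]1(C(=O)NS(=O)(=O)C2CC2)C[C@H]1C(F)F`, with difluoromethyl in place of ethyl on a saturated ring carbon. Among the compounds with values here, no measured compound carries difluoromethyl, so the data give no direct reading of this change. Within the data shown here, the only guide to size is a 2.3-fold higher number from compound 1 to compound 2 (0.36 log units; beyond the scatter), a single modest step at that same carbon with a different pair of groups. It gives no direction for the new change, so no shift beyond the scatter is expected in this assay, although a modest move either way remains possible. The expected change is no change at the digits printed from compound 2 to compound 3 (within the scatter).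

The estimate for compound 3 is 5 h, with an expected range of 2.5 h to 10 h.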

Compound 3, half-life: 0.8 h
The estimate for compound 3 lay 6.3-fold (0.80 log units) above the measured number; the whole stated range lies above it.
By their numbers in this assay, from the lowest: compound 3; then compound 1; then compound 2.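

At this saturated ring carbon of the three-membered ring, this assay now shows that the number can move down as well as up, with difluoromethyl in place of ethyl giving a 6.3-fold lower number from compound 2 to compound 3 (0.80 log units; beyond the scatter) and setting the position apart from the single rise seen before. Difluoromethyl in place of vinyl points the same way, with a 2.8-fold lower number from compound 1 to compound 3 (0.44 log units; beyond the scatter) on the same carbon, so among the three compounds the order from the highest number runs ethyl, vinyl, difluoromethyl, with no compound here going against it. Nothing measured here speaks to what lies behind this drop.

The compounds shown leave open whether the lower number goes with the fluorine atoms or with the single carbon attached to the ring, and a plain methyl group or a 2,2-difluoroethyl group at this carbon would separate the two readings. They also leave open how far the rise from vinyl to ethyl extends along a longer chain such as propyl, and where trifluoromethyl would fall relative to difluoromethyl.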